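From 3-ethoxyphenyl to 3,4-dimethoxyphenyl: working notes on compound 4

The source may hold more compounds than are shown below. What is called first, only, known or untested is meant among the compounds shown, and "the series" means these compounds.

Compound 1 `CCOC(=O)N1N=C(c2ccc(OC)cc2)CC1c1cc(OC)c(OC)c(OC)c1`: 8710 nM
Compound 2 `CCCOC(=O)N1N=C(c2cccc(O)c2)CC1c1cc(OC)c(OC)c(OC)c1`: > 10000 nM
Compound 3 `CCOc1cccc(C2=NN(C(=O)OC)C(c3cc(OC)c(OC)c(OC)c3)C2)c1`: 4970 nM

All three compounds were read in a functional assay on HeLa cells (Homo sapiens) for antiproliferative activity, read by MTT assay, with a stated time of 48 h; a higher number here means a weaker inhibitor of growth, a lower number a stronger inhibitor of growth. Compound 2 stands at > 10000 nM, which is a limit of the assay and not a number. Among the measured compounds shown here, only two compounds therefore give numbers. Compound 3 at 4970 nM and compound 1 at 8710 nM lie within the usual scatter of each other, so neither can be separated from the other in this assay.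

Compound 4 `COC(=O)N1N=C(c2ccc(OC)c(OC)c2)CC1c1cc(OC)c(OC)c(OC)c1` has 3,4-dimethoxyphenyl in place of the 3-ethoxyphenyl of compound 3, on a carbon with a double bond to nitrogen: 3,4-dimethoxyphenyl in place of 3-ethoxyphenyl on a carbon with a double bond to nitrogen. The methoxycarbonyl group stays as it is.

For the measured compounds named here, no pair of measured compounds differs in one place, so the series offers no direct measure of this change. The expectation rests on compound 3 at 4970 nM and compound 1 at 8710 nM, and no shift beyond the scatter is expected. The estimated move is a 1.2-fold higher number from compound 3 to compound 4 (0.08 log units; within the scatter). A result at the limit of the assay, as seen for compound 2, remains possible. In this assay the estimated value for compound 4 is 6000 nM, with an expected range of 2000 nM to 14000 nM.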

Compound 4, concentration for 50% growth inhibition: 3390 nM
For compound 4 the middle estimate is 1.8-fold (0.25 log units) above the measured one, and the stated range covers the measured number.
By their numbers in this assay, from the lowest: compounds 4, 3 and 1 (each within the scatter of the next, the first and the last beyond it). At a limit, above all of these: compound 2.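

Among the compounds shown here, the first step between compounds that differ in one place reads, in this assay, as a 1.5-fold lower number from compound 3 to compound 4 (0.17 log units; within the scatter), with 3,4-dimethoxyphenyl in place of 3-ethoxyphenyl on a carbon with a double bond to nitrogen and the methoxycarbonyl group unchanged. This position therefore takes either group with no shift that can be told from the scatter, even though the entering group carries one more heavy atom and one more hydrogen-bond acceptor than the leaving one. Nothing at hand gives a reason for the size of this step.

On these data alone, what remains open is whether a group of another kind on this phenyl ring, such as an amine or a carboxylic acid, would move the number beyond the scatter, since the pair here covers only 3-ethoxyphenyl and 3,4-dimethoxyphenyl. Also open is how the carbonyl-bearing group on the ring nitrogen contributes on its own, as no pair isolates that place and a longer chain such as butoxycarbonyl is not among the compounds shown.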